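The compounds below may be only part of what the source reports. "The series", "measured", "known", "first", "only" and "open" are said of these compounds alone.

Measured so far in a functional assay on MKN-45 cells (Homo sapiens) for cytotoxicity, read by MTT assay, with a stated time of 72 h; on this read-out lower numbers stand for stronger inhibition and higher numbers for weaker inhibition:

compound 1 `C=CCc1cccc(/C=N/NC(=O)Nc2ccc(Oc3ccnc4cc(OCCCN5CCCCC5)c(OC)cc34)c(F)c2)c1OC`: 670 nM
compound 2 `COc1cc2c(Oc3ccc(NC(=O)N/N=C/c4ccncc4)cc3F)ccnc2cc1OCCCN1CCCCC1`: 980 nM

Compound 2 holds the highest of the two numbers in this assay, and its nearest neighbour is compound 1, the pair lying within the scatter of each other. Compound 3 `COc1cc2c(Oc3ccc(NC(=O)N/N=C/c4cc5ccccc5[nH]4)cc3F)ccnc2cc1OCCCN1CCCCC1` differs from compound 2 in one place: 1H-indol-2-yl in place of pyridin-4-yl on a carbon with a double bond to nitrogen. For the measured compounds named here, the only measured step that bears on this position is a 1.5-fold higher number from compound 1 to compound 2 (0.17 log units; within the scatter), a change of the group on the same carbon with a double bond to nitrogen that left the number within the scatter. Going by the values given here, no step to a bicyclic group at this carbon has been measured, so the expectation rests on that single tolerant exchange. On this basis no step beyond the scatter is expected, and the expected step is a 1.2-fold lower number from compound 2 to compound 3 (0.09 log units; within the scatter). Compound 3 is therefore estimated at 800 nM, with a range of 250 nM to 2500 nM.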

Compound 3, half-maximal inhibitory concentration: 830 nM
The estimate for compound 3 lay 1.0-fold (0.02 log units) below the measured number; the measured number falls inside the stated range.
By their numbers in this assay, from the lowest: compounds 1, 3 and 2 (each within the scatter of the next).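

Working from this assay, the exchange of pyridin-4-yl for 1H-indol-2-yl gives a 1.2-fold lower number from compound 2 to compound 3 (0.07 log units; within the scatter) and the exchange of 3-allyl-2-methoxyphenyl for 1H-indol-2-yl gives a 1.2-fold higher number from compound 1 to compound 3 (0.09 log units; within the scatter) on the same carbon with a double bond to nitrogen. This position therefore also tolerates a group with one five-membered and one six-membered aromatic ring, and one that brings a hydrogen-bond donor, with all three compounds within the scatter of each other. No measured information bears on why these exchanges leave the number within the scatter.

On these data alone, whether a 1-methyl-1H-indol-2-yl group would give a number within the scatter of that of compound 3 remains open. So does whether an aliphatic amine, a carboxylic acid or a plain methyl group on this carbon would produce a step beyond the scatter.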